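The compounds below may be only part of what the source reports. "The series", "measured", "known", "first", "only" and "open" are said of these compounds alone.

Working notes on the series. All three measured compounds keep the shared core and differ only in the chain on the amide nitrogen. In a functional assay on A549 cells (Homo sapiens) for antiproliferative activity, read by MTT assay, with a stated time of 72 h (a lower number here means a stronger inhibitor, a higher number a weaker inhibitor), compound 1 `CNC(=O)c1cc(Oc2ccc(NC(=O)c3cc4cccnc4n(-c4ccccc4)c3=O)cc2)ccn1` gives 200 nM, compound 2 `CCNC(=O)c1cc(Oc2ccc(NC(=O)c3cc4cccnc4n(-c4ccccc4)c3=O)cc2)ccn1` gives 160 nM, and compound 3 `CCCNC(=O)c1cc(Oc2ccc(NC(=O)c3cc4cccnc4n(-c4ccccc4)c3=O)cc2)ccn1` gives 95 nM. Compound 3 thus holds the lowest of the three numbers: against compound 2 the gap is a 1.7-fold lower number from compound 2 to compound 3 (0.23 log units; within the scatter), against compound 1 it is a 2.1-fold lower number from compound 1 to compound 3 (0.32 log units; beyond the scatter), and between the first two it is a 1.3-fold lower number from compound 1 to compound 2 (0.10 log units; within the scatter).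

Compound 4 `CCCNC(=O)c1cc(Oc2ccc(NC(=O)c3cc4cccnc4n(-c4ccc(Cl)cc4)c3=O)cc2)ccn1` differs from compound 3 by chloro in place of hydrogen on an aromatic carbon. Going by the values given here, no measured step touches this position; all three steps sit on the amide chain, and even the largest of them is only modest. Nothing in the measured data therefore argues for a step beyond the scatter at this position in this assay, in either direction. The working expectation for compound 4 is a number close to that of compound 3, an expected step of a 1.1-fold lower number from compound 3 to compound 4 (0.05 log units; within the scatter), estimated at 85 nM with a range from 40 nM to 200 nM.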

Compound 4, half-maximal inhibitory concentration: 120 nM
The estimate for compound 4 lay 1.4-fold (0.15 log units) below the measured number; the measured number falls inside the stated range.
By their numbers in this assay, from the lowest: compounds 3, 4, 2 and 1 (each within the scatter of the next, the first and the last beyond it).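

Going by these compounds alone, the chloro group on the aromatic carbon, para to a large group, is the first change away from the amide chain, and in this assay it gives a 1.3-fold higher number from compound 3 to compound 4 (0.10 log units; within the scatter). This shows that the change from phenyl to 4-chlorophenyl on the chain of compound 3 can be made with the number staying within the scatter, so this position accepts this one atom without a readable shift in either direction. Nothing at hand offers an explanation for this result.

A single chloro group leaves open whether other groups at the same place, such as methoxy, an amine or a carboxylic acid, would also stay within the scatter. It also leaves open whether the same change would read alike with the shorter amide chains of compound 1 and compound 2, or with a butyl chain.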